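This account rests on a few compounds, and the source may have more. Where it says the series, first, only, none or still open, it means among the compounds named here.

Of the compounds shown here, three built on one shared core have been measured in an assay on isolated protein for displacement of a labelled ligand from 5-hydroxytryptamine receptor 6 (Homo sapiens); a higher number here means a weaker inhibitor, a lower number a stronger inhibitor. Compound 1 `CNS(=O)(=O)NC[C@@H]1CCCc2cc(S(=O)(=O)c3cccc(F)c3)ccc21` gives 1 nM, compound 2 `O=C(NC[C@@H]1CCCc2cc(S(=O)(=O)c3cccc(F)c3)ccc21)c1ccc[nH]1` gives 5.01 nM, and compound 3 `O=S(=O)(O)CCCNC[C@@H]1CCCc2cc(S(=O)(=O)c3cccc(F)c3)ccc21` gives 1.26 nM. Compound 3 lies close to compound 1, as the step of a 1.3-fold higher number from compound 1 to compound 3 (0.10 log units; within the scatter) shows, whereas the step of a 4.0-fold lower number from compound 2 to compound 3 (0.60 log units; beyond the scatter) is beyond the scatter. Compound 4 `NCC(=O)NC[C@@H]1CCCc2cc(S(=O)(=O)c3cccc(F)c3)ccc21` differs from compound 3 by (aminomethyl)carbonyl in place of 3-sulfopropyl on an amine nitrogen. Of the measured steps, a 5.0-fold higher number from compound 1 to compound 2 (0.70 log units; beyond the scatter) also placed a carbonyl group on that amine nitrogen and weakened binding modestly, while a 1.3-fold higher number from compound 1 to compound 3 (0.10 log units; within the scatter) made little difference. A similar modest loss is therefore expected, estimated as a 2.8-fold higher number from compound 3 to compound 4 (0.44 log units; beyond the scatter). Compound 4 is expected to give about 3.5 nM, with a likely range from 1.2 nM to 10 nM.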

Compound 4, inhibition constant: 0.316 nM
The estimate for compound 4 lay 11-fold (1.04 log units) above the measured number, outside the stated range (below it).
By their numbers in this assay, from the lowest: compound 4; then compounds 1 and 3 (each within the scatter of the next); then compound 2.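

A carbonyl on this amine nitrogen does not in itself weaken binding, as compound 2 suggested. The group on the carbonyl carbon matters, as the change to aminomethyl gives a 16-fold lower number from compound 2 to compound 4 (1.20 log units; beyond the scatter). The (aminomethyl)carbonyl group also outperforms the other two groups, with a 4.0-fold lower number from compound 3 to compound 4 (0.60 log units; beyond the scatter) and a 3.2-fold lower number from compound 1 to compound 4 (0.50 log units; beyond the scatter). No measurement available here explains this gain. Still open is whether the amine itself matters, since the compounds shown cannot tell how a hydroxymethyl group or a longer aminoethyl chain on that carbonyl carbon would compare.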